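A few compounds are considered here, and "the series" means these few. Any claim that something is new, unique, unknown or untested is made for them only; others in the source may bear on it.

Measured compounds in an ADME assay on the whole organism with Oryza sativa as the target, tested at 1 uM; on this read-out higher numbers stand for a weaker effect at the one concentration tested and lower numbers for a stronger effect: compound 1 `CCCc1ccc(NC(=O)N[C@H](C)c2ccccc2)cc1` gives 31%; compound 2 `CCCCc1ccc(NC(=O)N[C@H](C)c2ccccc2)cc1` gives 32%; compound 3 `C[C@@H](NC(=O)Nc1ccc(C(F)(F)F)cc1)c1ccccc1` gives 89%.

Compound 3 stands highest of the three, well apart from the others; compounds 1 and 2 sit close together. Compound 4 `C[C@@H](NC(=O)Nc1ccc(Br)cc1)c1ccccc1` differs from compound 3 by bromo in place of trifluoromethyl on an aromatic carbon. Among the compounds with values here, no measured step swaps one halogen-bearing group for another, so the closest guidance comes from a number 58 percentage points higher from compound 1 to compound 3 (beyond the scatter) and a number 57 percentage points higher from compound 2 to compound 3 (beyond the scatter), where trifluoromethyl on that aromatic carbon went with a large rise over propyl or butyl. Bromo is not a chain, so the expectation for compound 4 is that it remains nearer compound 3 than compounds 1 and 2, with a modest drop estimated as a number 14 percentage points lower from compound 3 to compound 4 (beyond the scatter). Compound 4 is therefore expected at 75%, within 50% to 95%.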

Compound 4, a percentage reported as activity, at one concentration (the size of the read-out at that concentration, not a potency): 95%
The estimate for compound 4 lay 20 percentage points below the measured number, within the range that was stated.
By their numbers in this assay, from the lowest: compounds 1 and 2 (each within the scatter of the next); then compounds 3 and 4 (each within the scatter of the next).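

In this assay, putting bromo, a single heavy atom, in place of the four-heavy-atom trifluoromethyl on this aromatic carbon gives a number 6 percentage points higher from compound 3 to compound 4 (within the scatter). Bromo stays far from the two chains, with a number 63 percentage points higher from compound 2 to compound 4 (beyond the scatter) and a number 64 percentage points higher from compound 1 to compound 4 (beyond the scatter), so these four compounds fall into two groups: propyl and butyl on one side, trifluoromethyl and bromo on the other. Nothing available explains this split. From the compounds shown here alone, whether a shorter chain such as methyl or ethyl would fall with the chains or with the other two remains open. So does the place of an amine or a methoxy group here.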